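The compounds below may be only part of what the source reports. "The series", "measured", "known", "first", "only" and "open" are said of these compounds alone.

Measured so far:
compound 1, `CCC(CC)CNc1c(C(N)=O)cnc2ccc(C#N)cc12` — in an assay on HT-29 cells for inhibition of Serine-protein kinase ATM (Homo sapiens), read by fluorescence, with a stated time of 1 h (on this read-out lower numbers stand for stronger inhibition and higher numbers for weaker inhibition), compound 1 gives 820 nM
compound 2, `NC(=O)c1cnc2ccc(-c3cccnc3)cc2c1NCC1CCCCC1` — in this assay compound 2 gives 456 nM

Among the compounds with values here, compound 1 sits at one end of the two numbers, with compound 2 as its only neighbour; the gap between the two is within the usual scatter, so the two cannot be told apart on these data.

Compound 3, `CCC(CC)CNc1c(C(N)=O)cnc2ccc(-c3ccc(C)nc3)cc12`, differs from compound 1 in one place: 6-methylpyridin-3-yl in place of cyano on an aromatic carbon. Within the data shown here, no pair of measured compounds isolates this change. Compound 2 carries a pyridin-3-yl at the same position of the shared core together with a different amine chain, and in this assay compound 2 gives 456 nM, which is no firm guide.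

For compound 3 a step toward a lower number is expected, a 2.0-fold lower number from compound 1 to compound 3 (0.29 log units; within the scatter), of a size that may not clear the scatter. Compound 3 is estimated at 420 nM, with a range from 150 nM to 1200 nM.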

Compound 3, half-maximal inhibitory concentration: 50 nM
For compound 3 the middle estimate is 8.4-fold (0.92 log units) above the measured one; the measured number lies below the stated range.
By their numbers in this assay, from the lowest: compound 3; then compounds 2 and 1 (each within the scatter of the next).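

The aromatic carbon that holds cyano in compound 1 proves to be a place where the substituent can shift the number strongly in this assay: 6-methylpyridin-3-yl in place of cyano gives a 16-fold lower number from compound 1 to compound 3 (1.21 log units; beyond the scatter), a large step beyond the scatter. The earlier two compounds could not show this, as they differ in more than one place and their numbers lie within the scatter of each other. Nothing measured here accounts for the step.

Within the data shown here, the single change swaps cyano for an aromatic ring and also adds a methyl group, so these compounds do not show which part of the new group goes with the step. A phenyl or a 6-methoxypyridin-3-yl at this carbon, on the amine chain of compound 1, remains an open comparison.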